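This account rests on a few compounds, and the source may have more. Where it says the series, first, only, none or still open, it means among the compounds named here.

Within the data shown here, in a functional assay on MCF7 cells (Homo sapiens) for cytotoxicity, read by MTT assay, with a stated time of 6 days (on this read-out higher numbers stand for an effect only at larger amounts of compound and lower numbers for an effect already at smaller amounts), compound 3 `COc1ccc2oc(-c3ccc([N+](=O)[O-])cc3)c(C(=O)O)c(=O)c2c1` gives 15.9 ug/mL, the only actual number so far. Compound 2 `O=C(O)c1c(-c2ccc([N+](=O)[O-])cc2)oc2ccccc2c1=O` reads > 25 ug/mL, which is a limit of the assay and not a number. Compound 1 `COC(=O)c1c(-c2ccc(O)cc2)oc2ccc(OC)cc2c1=O` reads > 25 ug/mL, again a limit.

The next compound is compound 4 `COc1ccc2oc(-c3ccc(O)cc3)c(C(=O)O)c(=O)c2c1`, and its difference from compound 3 is hydroxy in place of nitro on an aromatic carbon. This puts hydroxy in place of nitro on an aromatic carbon, para to a large group.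

Among the measured compounds shown here, no measured step covers this exchange. For the measured compounds named here, the nearest evidence is the one measured step, methoxy in place of hydrogen on an aromatic carbon, which is an at least 1.5-fold lower number from compound 2 to compound 3 (0.19 log units; that floor lies within the scatter). That is a different change, and its size cannot be carried over. Also relevant is the limit of > 25 ug/mL in this assay, at which 2 of the 3 values shown sit. Of the measured compounds, only compound 1 carries hydroxy, and its > 25 ug/mL is a limit.

This weak hint points towards a higher number in this assay, with a size that may not clear the usual scatter. The expected move is a 1.5-fold higher number from compound 3 to compound 4 (0.18 log units; within the scatter). A reading that returns only as a limit would be quite possible. For compound 4 the estimate is 24 ug/mL, with an expected range of 12 ug/mL to 45 ug/mL.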

Compound 4, concentration for half-maximal effect: > 25 ug/mL
Compound 4 ended at the assay's limit; the forecaster's own chance of this, stated with the estimate: 55%; middle value at least 1.0-fold (0.01 log units) away from the limit.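

In this assay, among these compounds, the first measured exchange at this position, para to a large group, replaces nitro with hydroxy and gives an at least 1.5-fold higher number from compound 3 to compound 4 (0.19 log units; that floor lies within the scatter), and that floor lies within the scatter. Among the compounds shown here, with the methoxy-bearing core and the free carboxylic acid held constant, the result therefore gives no firm evidence that the exchange costs activity, although compound 3 remains the only compound with an actual number. The ester-to-acid comparison, hydrogen in place of methyl on an oxygen next to a carbonyl group, adds no size for that change, because compound 1 and compound 4 both stand at the limit, which leaves their step unreadable: the limit of > 25 ug/mL in this assay, at which 3 of the 4 values shown sit.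

The compounds shown leave open how far the true values of the compounds at the limit lie from that of compound 3, and so how large the nitro-to-hydroxy step really is. They also leave open whether nitro is specifically needed at this position, a question that an amine or a chlorine atom there, on the same core as compound 3, could help to answer.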